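A few compounds are considered here, and "the series" means these few. Any claim that something is new, unique, unknown or untested is made for them only; others in the source may bear on it.

Measured so far in a functional assay on Molt4/C8 cells (Homo sapiens) for cytotoxicity; a higher number here means a weaker inhibitor, a lower number a stronger inhibitor:
- compound 1 `O=C(/C=C/C(=O)N1C/C(=C\c2ccccc2)C(=O)/C(=C/c2ccccc2)C1)Nc1ccc(Cl)c(Cl)c1`: 1700 nM
- compound 2 `O=C(/C=C/C(=O)N1C/C(=C\c2ccccc2)C(=O)/C(=C/c2ccccc2)C1)Nc1ccc([N+](=O)[O-])cc1`: 31000 nM
- compound 3 `CC(=O)c1ccc(NC(=O)/C=C/C(=O)N2C/C(=C\c3ccc([N+](=O)[O-])cc3)C(=O)/C(=C/c3ccc([N+](=O)[O-])cc3)C2)cc1`: 390 nM

Of these three, compound 3 holds the lowest number at 390 nM, under compound 1 at 1700 nM and compound 2 at 31000 nM. The next compound, compound 4 `Cc1cccc(C)c1NC(=O)/C=C/C(=O)N1C/C(=C\c2ccc([N+](=O)[O-])cc2)C(=O)/C(=C/c2ccc([N+](=O)[O-])cc2)C1`, keeps the core of compound 3 and carries 2,6-dimethylphenyl in place of 4-acetylphenyl on an amide-type nitrogen.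

Among the measured compounds shown here, only one measured step bears on this change. It is an 18-fold higher number from compound 1 to compound 2 (1.26 log units; beyond the scatter), a large step beyond the scatter, made at the same amide-type nitrogen when 4-nitrophenyl replaces 3,4-dichlorophenyl. That step shows that a change at this nitrogen can move the number a long way in this assay. However, it involves neither group of the present change, and it was measured on a different core. For the measured compounds named here, no measured pair isolates 4-acetylphenyl or 2,6-dimethylphenyl, so the size of the next step stays open.

With compound 3 already at the low end at 390 nM, a rise is the likelier direction, though a modest one. The expected step is a 2.3-fold higher number from compound 3 to compound 4 (0.36 log units; beyond the scatter). For compound 4 the estimated value is 900 nM, with an expected range of 200 nM to 4000 nM.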

Compound 4, half-maximal inhibitory concentration: 210 nM
Estimate against measurement, compound 4: 4.3-fold (0.63 log units) above; low and high end bracket the measured number.
By their numbers in this assay, from the lowest: compounds 4 and 3 (each within the scatter of the next); then compound 1; then compound 2.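

In this assay, 2,6-dimethylphenyl in place of 4-acetylphenyl on the amide-type nitrogen gives a 1.9-fold lower number from compound 3 to compound 4 (0.27 log units; within the scatter), so the two groups cannot be told apart on this core. The earlier step at this nitrogen, an 18-fold higher number from compound 1 to compound 2 (1.26 log units; beyond the scatter), had shown only that a change here can be large. The new pair shows that a change at the same nitrogen can also stay within the scatter, even though the carbonyl and hydrogen-bond acceptor of 4-acetylphenyl leave with it and the aromatic ring remains. No measurement offered here accounts for this result.

The compounds shown leave open whether 4-acetylphenyl and 2,6-dimethylphenyl would also read alike on the core of compound 1, where the one measured step at this nitrogen was large. They also leave open whether the number would hold if the aromatic ring on this nitrogen gave way to a carboxylic acid, an amine or a longer alkyl chain.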